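The source may hold more compounds than are shown below. What is called first, only, known or untested is meant among the compounds shown, and "the series" means these compounds.

Working notes on the series

Compound 1 `Cn1c(/C=C2\SC(=O)N(CC(=O)Nc3cc(C(C)(C)C)on3)C2=O)nc2ccccc21` is the reference point here. In a functional assay on PC-3 cells (Homo sapiens) for inhibition, read by MTT assay, with a stated time of 48 h (on this read-out higher numbers stand for weaker inhibition and lower numbers for stronger inhibition), compound 1 gives > 50000 nM, which is a limit of the assay and not a number. Its two neighbours in the set vary only the group on the aromatic nitrogen: compound 2 `CCn1c(/C=C2\SC(=O)N(CC(=O)Nc3cc(C(C)(C)C)on3)C2=O)nc2ccccc21` and compound 3 `CC(C)n1c(/C=C2\SC(=O)N(CC(=O)Nc3cc(C(C)(C)C)on3)C2=O)nc2ccccc21`. In this assay compound 2 gives > 50000 nM, again a limit. In this assay compound 3 gives > 50000 nM, also a limit. All three sit at the limit of > 50000 nM in this assay, at which 3 of the 3 values shown sit, so the steps a step that the two limits leave unreadable from compound 1 to compound 2, a step that the two limits leave unreadable from compound 1 to compound 3 and a step that the two limits leave unreadable from compound 2 to compound 3 cannot be sized.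

Compound 4 `Cn1c(/C=C2\SC(=O)N(CC(=O)Nc3nc(-c4ccccc4)cs3)C2=O)nc2ccccc21` changes a different part of the molecule, the group on the amide-type nitrogen: 4-phenyl-1,3-thiazol-2-yl in place of 5-(tert-butyl)-1,2-oxazol-3-yl on an amide-type nitrogen. Among the measured compounds shown here, none of the measured steps touches this position, and none of them is readable anyway, so no direction or size can be taken from them for this assay. The expectation for compound 4 therefore rests only on the limit of compound 1, with the change itself leaving either direction open. Compound 4 is estimated at 50000 nM, in the range 8000 nM to 150000 nM, which would mean an expected step of a number no higher from compound 1 to compound 4 (the limit leaves the size open).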

Compound 4, half-maximal inhibitory concentration: 39900 nM
Beside the measured number, compound 4's estimate is 1.3-fold (0.10 log units) above it; the measured number falls inside the stated range.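

Among the compounds shown here, compound 4 is the first to give a number rather than a limit in this assay, and it does so through a change on the amide-type nitrogen, a position the earlier compounds left untouched: the limit of > 50000 nM in this assay, at which 3 of the 4 values shown sit. Placing 4-phenyl-1,3-thiazol-2-yl in place of 5-(tert-butyl)-1,2-oxazol-3-yl gives an at least 1.2-fold lower number from compound 1 to compound 4 (0.09 log units; that floor lies within the scatter). This is a floor only, so the series shows that this position can yield a readable value, but not how large the step is.

The compounds shown leave open whether the thiazole ring or its phenyl group carries the change, which an unsubstituted 1,3-thiazol-2-yl group would separate. They also leave open whether the group on the aromatic nitrogen, unreadable so far, matters once 4-phenyl-1,3-thiazol-2-yl is in place.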